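The source may hold more compounds than are shown below. What is called first, only, known or untested is meant among the compounds shown, and "the series" means these compounds.

Measured so far in a physicochemical assay for acid dissociation:
compound 1 `CN1C=CN(C2NC(C(Cl)(Cl)Cl)=CN2c2ccc(S(N)(=O)=O)cc2)C=C1`: 7.68
compound 2 `CC1=CN(c2ccc(S(N)(=O)=O)cc2)C(N2C=CN(C)C=C2)N1`: 7.11
compound 3 `CN1C=CN(C2OC(C(Cl)(Cl)Cl)=CN2c2ccc(S(N)(=O)=O)cc2)C=C1`: 7.55

Compound 1 and compound 2 share a core and differ by methyl in place of trichloromethyl on a double-bonded ring carbon. That change gives a number 0.57 log units lower from compound 1 to compound 2 (beyond the scatter) in this assay.

Compound 3 carries a second core; the difference between the two cores is not broken down here. In this assay compound 3 and compound 1 lie within the scatter of each other, while compound 3 sits beyond the scatter from compound 2.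

Compound 4 `CC1=CN(c2ccc(S(N)(=O)=O)cc2)C(N2C=CN(C)C=C2)O1` is not yet measured. It stands to compound 3 as compound 2 stands to compound 1, by methyl in place of trichloromethyl on a double-bonded ring carbon. The place is not the same word for word: in compound 1 the ring is a five-membered non-aromatic ring with 2 nitrogen, next to the ring nitrogen; in compound 3 it is a five-membered non-aromatic ring with 1 nitrogen and 1 oxygen, next to the ring oxygen. So this is the same kind of change, not the same change.

Within the data shown here, the expectation rests on the single measured instance, because a number 0.57 log units lower from compound 1 to compound 2 (beyond the scatter) is the only step of this kind here. A step of about the same size, a number 0.55 log units lower from compound 3 to compound 4 (beyond the scatter), is expected for compound 4 in this assay, with added uncertainty from the changed ring. Compound 4 is estimated at 7, between 6.6 and 7.4.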

Compound 4, acid dissociation constant: 7.01
The estimate for compound 4 lay 0.01 log units below the measured number; the range from low to high includes it.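

In this assay, methyl in place of trichloromethyl on a double-bonded ring carbon gives a number 0.54 log units lower from compound 3 to compound 4 (beyond the scatter) and, on the core of compound 1, a number 0.57 log units lower from compound 1 to compound 2 (beyond the scatter); the change therefore carries from one core to the other in the same direction and with a step of close size. This rests on two matched pairs on two cores, so it does not show that the step would hold on a further core, or that it would apply to any other pair of groups at this place. Nothing at hand gives a cause for the step on either core.

The compounds shown leave open how a trifluoromethyl group, an amine, a carboxylic acid or a longer chain on the same double-bonded ring carbon would stand in this assay. They also leave open whether any of these groups would give matching steps on the two cores, as methyl and trichloromethyl do.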